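The compounds below may be only part of what the source reports. "The series", "measured", "known", "first", "only" and "open" are said of these compounds alone.

Compound 1 `O=c1oc2ccccc2c2nc3c(ccc4cc[nH]c43)c(-c3ccc(O)cc3)c12` and compound 2 `O=c1oc2ccccc2c2nc3c(ccc4cc[nH]c43)c(-c3ccc(Cl)cc3Cl)c12` share one core and differ only in the aromatic group attached to it. Going by the values given here, in a functional assay on B16-F10 cells (Mus musculus) for cytotoxicity (a higher number here means a weaker inhibitor, a lower number a stronger inhibitor), compound 1 gives 70700 nM and compound 2 gives 70700 nM as its result, so compound 2 stands level with compound 1 on the numbers so far. Compound 3 `O=c1oc2ccccc2c2nc3c(ccc4cc[nH]c43)c(-c3ccccc3Br)c12` keeps the same core but has 2-bromophenyl in place of 2,4-dichlorophenyl on an aromatic carbon, at the same carbon that differs between compound 1 and compound 2.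

Among the compounds with values here, only one measured step bears on this change: no change at the digits printed from compound 1 to compound 2 (within the scatter) with 2,4-dichlorophenyl in place of 4-hydroxyphenyl. Within the data shown here, one step is slim evidence, and no compound measured so far carries a 2-bromophenyl group. Even so, that single step showed no shift beyond the scatter, so none is expected in this assay for this swap either. The estimated change is a 1.1-fold lower number from compound 2 to compound 3 (0.04 log units; within the scatter) and it remains uncertain. Compound 3 is therefore estimated at 65000 nM with an expected range from 22000 nM to 150000 nM as the likely span of the measurement.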

Compound 3, half-maximal inhibitory concentration: 70700 nM
Beside the measured number, compound 3's estimate is 1.1-fold (0.04 log units) below it, and the stated range covers the measured number.
By their numbers in this assay, from the lowest: compounds 1, 2 and 3 (each within the scatter of the next).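

In this assay, replacing the two chlorine atoms of 2,4-dichlorophenyl with the single bromine of 2-bromophenyl gives no change at the digits printed from compound 2 to compound 3 (within the scatter), so this second change at the carbon opposite the ring nitrogen also leaves the result unmoved. Going by these compounds alone, the comparison with the first compound reads the same, no change at the digits printed from compound 1 to compound 3 (within the scatter), which means that three differently substituted phenyl groups at this carbon, carrying a hydroxyl, two chlorines or one bromine, now give the same printed result, where before there was only a single pair to compare. There is no measured information to explain this lack of difference.

The compounds shown leave open whether a group of another kind at this carbon, such as an amine, a carboxylic acid or a longer alkyl chain in place of the phenyl ring, would shift the number in this assay. They also leave open whether changes elsewhere on the shared core would do so, as all three compounds differ only at this one carbon.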